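The compounds below may be only part of what the source reports. "The series", "measured", "known", "first", "only" and "open" are said of these compounds alone.

Measured compounds:
- compound 1 `Nc1nc2c(ncn2/C=C2\C[C@@H]2[C@H](O)CO)c(=O)[nH]1`: 67000 nM
- compound 2 `Nc1nc2c(ncn2/C=C2\C[C@@H]2[C@@H](O)CO)c(=O)[nH]1`: 61000 nM
- compound 3 `Nc1nc2c(ncn2/C=C2/C[C@H]2[C@H](O)CO)c(=O)[nH]1`: 62600 nM

All three values come from an ADME assay on Akata cells (Homo sapiens) for cytotoxicity; on this read-out lower numbers stand for higher toxicity in this test and higher numbers for lower toxicity in this test. The three compounds share every atom and bond and differ only in configuration as drawn. The steps between them are small: a 1.1-fold lower number from compound 1 to compound 2 (0.04 log units; within the scatter), a 1.1-fold lower number from compound 1 to compound 3 (0.03 log units; within the scatter) and a 1.0-fold higher number from compound 2 to compound 3 (0.01 log units; within the scatter). Each of these stereo-only changes leaves the read-out inside the scatter, as the pairs differ only in configuration (the fact that compounds 1 and 2 differ only in the configuration as drawn, (the fact that compounds 1 and 3 differ only in the configuration as drawn), (the fact that compounds 2 and 3 differ only in the configuration as drawn)). Compound 3 sits among the three with its nearest neighbour compound 2 and its furthest neighbour compound 1, both separations within the scatter.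

Compound 4 `Nc1nc2c(ncn2/C=C2\C[C@H]2[C@H](O)CO)c(=O)[nH]1` is not yet measured. Its relation to compound 3: the two compounds have the same atoms and bonds and differ only in configuration as drawn: 1 of 3 stereo elements differ; a double bond is drawn Z in compound 3 and E in compound 4. The steps from compound 1 to compound 3 and from compound 2 to compound 3 already contain a change of double-bond geometry, and both stayed within the scatter. The expected step for compound 4 is therefore a 1.0-fold higher number from compound 3 to compound 4 (0.00 log units; within the scatter), that is, none beyond the scatter. Compound 4 is expected to give about 63000 nM in this assay, with a range of 35000 nM to 115000 nM.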

Compound 4, half-maximal cytotoxic concentration: 86600 nM
Compound 4: middle estimate off by 1.4-fold (0.14 log units), on the low side; the range from low to high includes it.
By their numbers in this assay, from the lowest: compounds 2, 3, 1 and 4 (each within the scatter of the next).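

For the compounds shown here, the double-bond geometry is read alone here for the first time, as the earlier steps carried it together with stereocentre changes; in this assay, going from Z to E gives a 1.4-fold higher number from compound 3 to compound 4 (0.14 log units; within the scatter): the fact that compounds 3 and 4 differ only in the configuration as drawn. Going by these compounds alone, the ring stereocentre is also read alone for the first time, with a 1.3-fold higher number from compound 1 to compound 4 (0.11 log units; within the scatter), while changing the ring and chain stereocentres together gives a 1.4-fold higher number from compound 2 to compound 4 (0.15 log units; within the scatter). None of the three stereo elements therefore moves this assay beyond the scatter, whether changed singly or in the combinations shown.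

As far as these compounds go, only configuration varies across these compounds, so it remains open whether the read-out responds to a change of constitution, such as an amine or a carboxylic acid in place of a hydroxyl group. From the compounds shown here alone, whether the same flat picture holds in other cell types also remains open.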